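The compounds below may be only part of what the source reports. "The series", "measured", "known", "first", "only" and "open" are said of these compounds alone.

Measured compounds in a functional assay on HT-1080 cells (Homo sapiens) for antiproliferative activity, read by sulforhodamine B assay, with a stated time of 48 h; on this read-out higher numbers stand for weaker inhibition and lower numbers for stronger inhibition:
- compound 1 `CC(=O)Nc1ccc(S(=O)(=O)Oc2ccccc2I)cc1` gives 17000 nM
- compound 2 `CCC(=O)Nc1ccc(S(=O)(=O)Oc2ccccc2I)cc1` gives 7200 nM
- compound 3 `O=C(CCl)Nc1ccc(S(=O)(=O)Oc2ccccc2I)cc1` gives 600 nM

Compound 3 stands at the lowest number of the three in this assay; its nearest neighbour is compound 2, and the steps to both others are beyond the scatter (a 12-fold lower number from compound 2 to compound 3 (1.08 log units; beyond the scatter); a 28-fold lower number from compound 1 to compound 3 (1.45 log units; beyond the scatter)). Within the measured set, the chloro group on the saturated chain carbon bound to the carbonyl carbon goes with the low number, while the methyl step (a 2.4-fold lower number from compound 1 to compound 2 (0.37 log units; beyond the scatter)) was only modest.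

Compound 4 `CCNC(=O)Nc1ccc(S(=O)(=O)Oc2ccccc2I)cc1` differs from compound 3 by ethylamino in place of chloromethyl on a carbonyl carbon, which turns the ((chloromethyl)carbonyl)amino of compound 3 into an (ethylcarbamoyl)amino. Going by the values given here, the chloro is gone, so the steps that bear on this change are the two that brought it in, both large toward lower numbers. Reversing them, a large step toward higher numbers is expected in this assay, with compound 4 estimated to land in the region of compounds 1 and 2 rather than of compound 3. For compound 4 the expected number is 8000 nM, with a range of 2500 nM to 25000 nM. This corresponds to an expected step of a 13-fold higher number from compound 3 to compound 4 (1.12 log units; beyond the scatter).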

Compound 4, half-maximal inhibitory concentration: 140 nM
Beside the measured number, compound 4's estimate is 57-fold (1.76 log units) above it, outside the stated range (below it).
By their numbers in this assay, from the lowest: compound 4; then compound 3; then compound 2; then compound 1.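

In this assay the low numbers at this carbonyl carbon do not depend on the chloromethyl group: ethylamino in its place goes further (a 4.3-fold lower number from compound 3 to compound 4 (0.63 log units; beyond the scatter)), and compound 4 holds the lowest number of the four without any chloro. Against the plain carbon groups on the same carbonyl carbon, the change is far larger (a 51-fold lower number from compound 2 to compound 4 (1.71 log units; beyond the scatter); a 120-fold lower number from compound 1 to compound 4 (2.08 log units; beyond the scatter)), and the first of these steps swaps ethyl for ethylamino, so the two groups differ only by the added nitrogen with its hydrogen. No measured data on the series bear on why the ethylamino group gives this result.

From the compounds shown here alone, whether the gain rests on that amino hydrogen or on the ethyl chain remains open; methylamino, propylamino and dimethylamino at this carbon would separate the two. Also open, going by these compounds, is whether a 2-chloroethylamino group would combine the chloro and ethylamino steps.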